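The source may hold more compounds than are shown below. What is called first, only, known or untested is meant among the compounds shown, and "the series" means these compounds.

Measured compounds:
- compound 1, `CCC(C)(C)Cc1c[nH]c(CCc2ccc(-c3ccncc3)cc2)n1`: 103 nM
- compound 2, `CCC(C)(C)Cc1c[nH]c(CCc2ccc(-n3ccnn3)cc2)n1`: 111 nM
- compound 3, `CCC(C)(C)Cc1c[nH]c(CCc2ccc(-c3cnccn3)cc2)n1`: 107 nM

All three share one core and differ only in the group on the aromatic carbon at the far end of the molecule. In a functional assay on HEK293 cells for agonist activity at Bombesin receptor subtype-3 (Mus musculus), read by luminescence and calcium flux, with a stated time of 10 min (a lower number here means that less compound is needed, a higher number that more compound is needed for the effect), compound 1 gives 103 nM, compound 2 gives 111 nM and compound 3 gives 107 nM. Compound 3 stands second highest of the three numbers, but its nearest neighbour compound 2 and its furthest neighbour compound 1 both lie within the scatter of it, so the three values cannot be ordered.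

Compound 4, `CCC(C)(C)Cc1c[nH]c(CCc2ccc(-c3csnn3)cc2)n1`, has not yet been measured. It differs from compound 3 as follows: 1,2,3-thiadiazol-4-yl in place of pyrazin-2-yl on an aromatic carbon

The steps measured so far all bear on this kind of exchange of one aromatic group for another at the same position: a 1.1-fold higher number from compound 1 to compound 2 (0.03 log units; within the scatter), a 1.0-fold higher number from compound 1 to compound 3 (0.02 log units; within the scatter) and a 1.0-fold lower number from compound 2 to compound 3 (0.02 log units; within the scatter). Each of them lies within the scatter, including the exchange of a six-membered ring for a five-membered ring from compound 1 to compound 2. No step beyond the scatter is therefore expected in this assay for compound 4.

Compound 4 is estimated at 110 nM, with a range from 55 nM to 220 nM, which means an expected step of a 1.0-fold higher number from compound 3 to compound 4 (0.01 log units; within the scatter).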

Compound 4, half-maximal effective concentration: 109 nM
Compound 4: the middle estimate sits 1.0-fold (0.00 log units) above what was measured; low and high end bracket the measured number.
By their numbers in this assay, from the lowest: compounds 1, 3, 4 and 2 (each within the scatter of the next).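

In this assay, going by these compounds alone, 1,2,3-thiadiazol-4-yl, the first group to bring a sulfur atom into the ring, gives a 1.0-fold higher number from compound 3 to compound 4 (0.01 log units; within the scatter), and its comparison with the two other groups gives a 1.0-fold lower number from compound 2 to compound 4 (0.01 log units; within the scatter) and a 1.1-fold higher number from compound 1 to compound 4 (0.02 log units; within the scatter). Within the data shown here, the tolerance seen among the earlier compounds therefore extends to a five-membered aromatic ring with sulfur among its hetero atoms: on this aromatic carbon, para to a large group, all four rings lie within the scatter of one another, and their values cannot be ordered. The data shown offer no measurement that would explain why these different rings give such closely matching numbers.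

As far as these compounds go, all four groups are aromatic rings with hetero atoms, so it remains open whether an amine, a carboxylic acid or a longer chain at this position would give a step beyond the scatter. All four compounds also share one core, which leaves open whether these exchanges would remain within the scatter if the chain on that core were replaced by a different one.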